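A few compounds are considered here, and "the series" means these few. Any claim that something is new, unique, unknown or untested is made for them only; others in the source may bear on it.

Measured so far in an assay with Cystic fibrosis transmembrane conductance regulator (Rattus norvegicus) as the target; a lower number here means tighter binding, a higher number weaker binding:
- compound 1, `COc1ccc(COc2ccccc2C2=NOC(CCl)C2)cc1`: 59000 nM
- compound 2, `COC(=O)C1CC(c2ccccc2OCc2ccc(OC)cc2)=NO1`: 50000 nM
- compound 3, `COc1cccc(COc2ccccc2-c2cc(CO)on2)c1`: 72000 nM

All three numbers lie within the scatter of one another, so compound 2 cannot be set apart from compound 1 or compound 3 on these data. Among the compounds with values here, the only single-point step recorded, a 1.2-fold lower number from compound 1 to compound 2 (0.07 log units; within the scatter), is within the scatter; it concerns a substituent on a saturated ring carbon, not the position at issue here.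

Compound 4, `COC(=O)C1CC(c2ccccc2OCc2cccc(OC)c2)=NO1`, differs from compound 2 by 3-methoxyphenyl in place of 4-methoxyphenyl on a saturated chain carbon bound to an oxygen on an aromatic ring. Within the data shown here, no measured pair isolates this change. Compound 3 carries the 3-methoxyphenyl group but differs from compound 2 in other places as well, so its value tells nothing specific about the move of the methoxy group; in this assay compound 3 gives 72000 nM, again within the scatter of the other two.

With every recorded step and every pairwise gap inside the scatter, no step beyond the scatter is expected in this assay for this change either; the expected step is a 1.1-fold higher number from compound 2 to compound 4 (0.04 log units; within the scatter). Compound 4 is estimated at 55000 nM, with a range from 25000 nM to 120000 nM.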

Compound 4, dissociation constant: 110000 nM
For compound 4 the middle estimate is 2.0-fold (0.30 log units) below the measured one; the range from low to high includes it.
By their numbers in this assay, from the lowest: compounds 2, 1, 3 and 4 (each within the scatter of the next, the first and the last beyond it).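

In this assay, this position responds to where the methoxy group sits: 3-methoxyphenyl in place of 4-methoxyphenyl on a saturated chain carbon bound to an oxygen on an aromatic ring gives a 2.2-fold higher number from compound 2 to compound 4 (0.34 log units; beyond the scatter), a modest step and the only one recorded beyond the scatter. The earlier step at the saturated ring carbon stayed within the scatter, so the series now has one place where a change can be read, though only just. Compounds 2 and 4 have the same atoms, and the leaving and entering groups have the same counts, so the step comes with a rearrangement alone, and no supporting measurement accounts for it.

Going by these compounds, a single pair supports this reading, so it remains open whether the same change would give a similar step with chloromethyl in place of methoxycarbonyl on the saturated ring carbon. On these data alone, it is also open how this place would respond to a plain phenyl, or to a phenyl carrying an amine or a carboxylic acid, and whether any such group would move the number further in either direction.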